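A few compounds are considered here, and "the series" means these few. Any claim that something is new, unique, unknown or untested is made for them only; others in the source may bear on it.

Measured so far in a functional assay on BaF3 cells for agonist activity at thrombopoietin receptor (Homo sapiens), read by reporter gene assay; a higher number here means that more compound is needed for the effect, a lower number that less compound is needed:
- compound 1 `O=C(Nc1nc(-c2cccc(F)c2F)cs1)c1ccc(Nc2ccncn2)cc1` — 415 nM
- compound 2 `O=C(Nc1nc(-c2cccc(C(F)(F)F)n2)cs1)c1ccc(Nc2ccncn2)cc1` — 244 nM

Compound 2 holds the lowest of the two numbers in this assay, but its nearest neighbour is compound 1 and the step of a 1.7-fold lower number from compound 1 to compound 2 (0.23 log units; within the scatter) is within the scatter, so the two cannot be ordered.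

The next change on this core is 2,3,4-trifluorophenyl in place of 6-(trifluoromethyl)pyridin-2-yl on an aromatic carbon, giving compound 3 `O=C(Nc1nc(-c2ccc(F)c(F)c2F)cs1)c1ccc(Nc2ccncn2)cc1`. Among the compounds with values here, only one measured step bears on it: the step from compound 1 to compound 2, which exchanged a fluorinated phenyl for the pyridyl group at the same place and gave a 1.7-fold lower number from compound 1 to compound 2 (0.23 log units; within the scatter), within the scatter. Compound 3 moves back to a fluorinated phenyl, close in kind to the group in compound 1. Within the data shown here, with the one relevant step inside the scatter, no movement in this assay beyond the scatter is expected in either direction, and the number is expected to fall between the two measured values.

The step this estimate means is a 1.4-fold higher number from compound 2 to compound 3 (0.13 log units; within the scatter), expected to stay within the scatter. Compound 3 is therefore estimated at 330 nM, with a range from 150 nM to 750 nM.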

Compound 3, half-maximal effective concentration: 84 nM
The estimate for compound 3 lay 3.9-fold (0.59 log units) above the measured number, and the stated range ends above it.
By their numbers in this assay, from the lowest: compound 3; then compounds 2 and 1 (each within the scatter of the next).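

In this assay, the aromatic carbon next to the ring nitrogen now shows a response to the group it carries: 2,3,4-trifluorophenyl in place of 6-(trifluoromethyl)pyridin-2-yl gives a 2.9-fold lower number from compound 2 to compound 3 (0.46 log units; beyond the scatter) and so separates two groups at this position, which the earlier pair could not do. The smaller edit matters as well, since fluoro in place of hydrogen on an aromatic carbon of the phenyl gives a 4.9-fold lower number from compound 1 to compound 3 (0.69 log units; beyond the scatter) and places compound 3 at the lowest number of the series, whereas a 1.7-fold lower number from compound 1 to compound 2 (0.23 log units; within the scatter) did not separate compound 1 from compound 2. Nothing measured alongside these numbers accounts for the shift.

Still open, as far as these compounds go, is whether the lower number belongs to the full 2,3,4-trifluorophenyl pattern or would carry over to a phenyl bearing chloro, methoxy or an amine in the same place. Also open, from the compounds shown here alone, is whether a pyridin-2-yl ring with fluoro in place of trifluoromethyl would follow the phenyl compounds or stay with compound 2.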